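Dichlorophenyl Variant of a Pyridazinone Amide Series

This account rests on a few compounds, and the source may have more. Where it says the series, first, only, none or still open, it means among the compounds named here.

Measured compounds:
Compound 1 `COc1cc2c(Oc3ccc(NC(=O)c4nn(-c5ccccc5)c(=O)cc4C)cc3F)ccnc2cc1OCCCN1CCCCC1`, which in a functional assay on U-87MG ATCC cells (Homo sapiens) for inhibition, read by MTT assay, with a stated time of 72 h (on this read-out lower numbers stand for stronger inhibition and higher numbers for weaker inhibition), gives 1370 nM.
Compound 2 `COc1cc2c(Oc3ccc(NC(=O)c4nn(-c5ccccc5C(F)(F)F)c(=O)cc4C)cc3F)ccnc2cc1OCCCN1CCCCC1`, which in this assay gives 1150 nM.
Compound 3 `COc1ccc(-n2nc(C(=O)Nc3ccc(Oc4ccnc5cc(OCCCN6CCCCC6)c(OC)cc45)c(F)c3)c(C)cc2=O)cc1`, which in this assay gives 1800 nM.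

Compound 3 sits within the scatter of both neighbours: a 1.3-fold higher number from compound 1 to compound 3 (0.12 log units; within the scatter) and a 1.6-fold higher number from compound 2 to compound 3 (0.19 log units; within the scatter). Compound 4 `COc1cc2c(Oc3ccc(NC(=O)c4nn(-c5ccc(Cl)cc5Cl)c(=O)cc4C)cc3F)ccnc2cc1OCCCN1CCCCC1` differs from compound 3 by 2,4-dichlorophenyl in place of 4-methoxyphenyl on an aromatic nitrogen. Within the data shown here, the steps that bear on this position are a 1.6-fold higher number from compound 2 to compound 3 (0.19 log units; within the scatter) and a 1.2-fold lower number from compound 1 to compound 2 (0.08 log units; within the scatter), and neither moves the number beyond the scatter. Because a 1.6-fold higher number from compound 2 to compound 3 (0.19 log units; within the scatter) was within the scatter, the expectation for compound 4 is a 1.4-fold lower number from compound 3 to compound 4 (0.14 log units; within the scatter), no step beyond the scatter in this assay. Compound 4 is therefore estimated at 1300 nM, within a range of 600 nM to 2800 nM.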

Compound 4, half-maximal inhibitory concentration: 1800 nM
Compound 4: the middle estimate sits 1.4-fold (0.14 log units) below what was measured; low and high end bracket the measured number.
By their numbers in this assay, from the lowest: compounds 2, 1, 3 and 4 (each within the scatter of the next).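

With 2,4-dichlorophenyl on the aromatic nitrogen, the series stays flat in this assay: no change at the digits printed from compound 3 to compound 4 (within the scatter), a 1.6-fold higher number from compound 2 to compound 4 (0.19 log units; within the scatter) and a 1.3-fold higher number from compound 1 to compound 4 (0.12 log units; within the scatter). Compound 4 thus extends the earlier picture to a phenyl carrying two chlorine atoms, and all four aryl groups now lie within the scatter of one another. No measurement shown explains this flatness. From the compounds shown here alone, it remains open whether a phenyl bearing an amine or a carboxylic acid, or a cyclohexyl group in place of the phenyl, would give a step beyond the scatter at this position.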